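Near the Limit: From 3-Cyanophenyl to 4-Iodophenyl

A few compounds are considered here, and "the series" means these few. Any claim that something is new, unique, unknown or untested is made for them only; others in the source may bear on it.

In an ADME assay on MDBK cells (Bos taurus) for cytotoxicity (on this read-out lower numbers stand for higher toxicity in this test and higher numbers for lower toxicity in this test), compound 1 `Cc1ccccc1Cn1ccc2nc(-c3ccccc3)nc-2c1` gives > 100000 nM as a limit of the assay, not a number. Compound 2 `Brc1cccc(Cn2ccc3nc(-c4ccccc4)nc-3c2)c1` gives 85000 nM as a measured number. Compound 3 `N#Cc1cccc(Cn2ccc3nc(-c4ccccc4)nc-3c2)c1` gives > 100000 nM as a limit too and so sits at the limit of > 100000 nM in this assay, at which 2 of the 3 values shown sit, without an exact number. Compound 4 `Ic1ccc(Cn2ccc3nc(-c4ccccc4)nc-3c2)cc1` has 4-iodophenyl in place of 3-cyanophenyl on a saturated chain carbon bound to an aromatic nitrogen. Going by the values given here, two measured steps bear on this change. They are an at least 1.1-fold lower number from compound 1 to compound 2 (0.07 log units; that floor lies within the scatter) and an at least 1.1-fold higher number from compound 2 to compound 3 (0.07 log units; that floor lies within the scatter) and both stay within the scatter. No step beyond the scatter is therefore expected in this assay and the expected change is an at least 1.1-fold lower number from compound 3 to compound 4 (0.07 log units; that floor lies within the scatter) at most a small one. Compound 4 is estimated at 85000 nM within a range of 40000 nM to 100000 nM and may also come out only as a limit.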

Compound 4, half-maximal cytotoxic concentration: 22000 nM
Compound 4: the middle estimate sits 3.9-fold (0.59 log units) above what was measured; measured number outside the range, below it.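

The change to 4-iodophenyl on a saturated chain carbon bound to an aromatic nitrogen gives an at least 4.5-fold lower number from compound 3 to compound 4 (0.65 log units; beyond the scatter) and a 3.9-fold lower number from compound 2 to compound 4 (0.59 log units; beyond the scatter) and an at least 4.5-fold lower number from compound 1 to compound 4 (0.65 log units; beyond the scatter) in this assay as the first steps at this position shown to lie beyond the scatter. Two of these steps are only floors because they start from a limit of the assay: the limit of > 100000 nM in this assay, at which 2 of the 4 values shown sit.

The compounds shown cannot separate the effect of iodo from that of its place on the ring. On these data alone, how an amine or a carboxylic acid on that ring would read also stays open.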